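Estimating compound 4 from a single measured step

The source may report more compounds than this note shows. Statements on the series, on what has been measured and on what is new or still open speak of the compounds shown alone.

In an ADME assay on J774.A1 cells (Mus musculus) for cytotoxicity, read by MTT assay, with a stated time of 48 h (on this read-out lower numbers stand for higher toxicity in this test and higher numbers for lower toxicity in this test), compound 1 `COC(=O)c1c([N+](=O)[O-])noc1-c1ccc(C(F)(F)F)cc1` has no number, its entry reading "not determined" (no result reported). Compound 2 `O=C(Nc1ccccc1)c1c([N+](=O)[O-])noc1-c1ccc(Cl)cc1` gives 89300 nM. Compound 3 `O=C(Nc1ccccc1)c1c([N+](=O)[O-])noc1-c1ccc(Cl)cc1Cl` gives 67300 nM, which lies within the scatter of compound 2, so the two stand level in this assay.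

The next structure, compound 4 `O=C(NCc1cccc(Br)c1)c1c([N+](=O)[O-])noc1-c1ccc(Cl)cc1Cl`, changes compound 3 at the amide: 3-bromobenzyl in place of phenyl on an amide-type nitrogen. In words, 3-bromobenzyl takes the place of phenyl on an amide-type nitrogen, which turns anilino into (3-bromobenzyl)amino.

Among the measured compounds shown here, only one measured step is available, a 1.3-fold lower number from compound 2 to compound 3 (0.12 log units; within the scatter). That step is chloro in place of hydrogen on an aromatic carbon, so it does not touch the amide-type nitrogen and bears on the new change only indirectly. The data therefore give no measured size for this replacement, and no shift beyond the scatter is expected in either direction. The estimated outcome is a 1.2-fold lower number from compound 3 to compound 4 (0.09 log units; within the scatter), held loosely. Compound 4 is expected at 55000 nM, with an estimated range from 18000 nM to 140000 nM.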

Compound 4, half-maximal cytotoxic concentration: 71200 nM
The estimate for compound 4 lay 1.3-fold (0.11 log units) below the measured number; measured number inside the range.
By their numbers in this assay, from the lowest: compounds 3, 4 and 2 (each within the scatter of the next).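

The amide-type nitrogen, which the earlier step left untouched, now has a measured replacement: in this assay, 3-bromobenzyl in place of phenyl gives a 1.1-fold higher number from compound 3 to compound 4 (0.02 log units; within the scatter) and leaves compound 3 and compound 4 level. This position therefore accepts the exchange of anilino for (3-bromobenzyl)amino, a group of 8 heavy atoms in place of one of 6, with no shift beyond the scatter. Nothing among the data shown accounts for this lack of a shift.

The compounds shown do not tell whether a plain benzyl group would read the same as 3-bromobenzyl, so the bromine cannot be separated from the rest of the change. As far as these compounds go, it also stays open whether an amine, a carboxylic acid or a longer chain on this amide-type nitrogen would keep the number level.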